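Amide Variation Around an Inactive Starting Point

The source may hold more compounds than are shown below. What is called first, only, known or untested is meant among the compounds shown, and "the series" means these compounds.

Compound 1 `CCCN(C(=O)CN(C)C(=O)c1ccc(S(C)(=O)=O)c([N+](=O)[O-])c1)c1ccccc1`: > 60000 nM in an assay on isolated protein for inhibition of thyroid hormone receptor beta (Homo sapiens), read by fluorescence polarization; on this read-out higher numbers stand for weaker inhibition and lower numbers for stronger inhibition
Compound 2 `CN(Cc1ccccc1F)C(=O)C1CCN(C(=O)c2ccc(S(C)(=O)=O)c([N+](=O)[O-])c2)CC1`: > 60000 nM in this assay

Compound 1 stands at a limit of this assay rather than at a measured number, and the same is true of compound 2. This situation is summed up by the limit of > 60000 nM in this assay, at which 2 of the 2 values shown sit, so neither compound offers a point from which a direction could be read. Going by the values given here, no step between measured compounds can be stated.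

Compound 3 `CN(CC(=O)N1CCc2ccccc2C1)C(=O)c1ccc(S(C)(=O)=O)c([N+](=O)[O-])c1` differs from compound 1 by 1,2,3,4-tetrahydroisoquinolin-2-yl in place of phenyl(propyl)amino on a carbonyl carbon. Since compound 1 reached only a limit, the step from compound 1 to compound 3 in this assay cannot be expressed as a measured change. With both known compounds at the limit, compound 3 is expected to sit there as well, giving an estimated 60000 nM with a range from 20000 nM to 120000 nM. The step expected from compound 1 to compound 3 is a number no higher from compound 1 to compound 3 (the limit leaves the size open), which means no change beyond the scatter.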

Compound 3, half-maximal inhibitory concentration: > 60000 nM
Compound 3: a limit, no number; the forecaster's own chance of this, stated with the estimate: 80%; the middle value sits exactly at the limit.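

Compound 3 gives > 60000 nM in this assay, which is a limit and not a number. Going by these compounds alone, no step from compound 1 to compound 3 can be read, and the three compounds share one limit: the limit of > 60000 nM in this assay, at which 3 of the 3 values shown sit. The compounds shown leave open which change to the shared core, if any, would give a measurable value in this assay.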